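Aryl replacement from compound 2 to compound 3

This account rests on a few compounds, and the source may have more. Where it says the series, first, only, none or still open, it means among the compounds named here.

Compound 1 (`COc1ccc(-c2c3ccc4cc[nH]c4c3nc3c2c(=O)oc2ccccc23)cc1`) and compound 2 (`O=c1oc2ccccc2c2nc3c(ccc4cc[nH]c43)c(-c3ccc(F)cc3)c12`) share one core and differ only in the aryl group it carries. In a functional assay on B16-F10 cells (Mus musculus) for cytotoxicity (on this read-out higher numbers stand for weaker inhibition and lower numbers for stronger inhibition), compound 1 gives 70700 nM. Among the compounds with values here, compound 2 (70700 nM) stands level with compound 1, the only other compound measured so far.

Compound 3 (`O=c1oc2ccccc2c2nc3c(ccc4cc[nH]c43)c(-c3cccc(Cl)c3Cl)c12`) carries 2,3-dichlorophenyl in place of 4-fluorophenyl on an aromatic carbon, opposite the ring nitrogen: 2,3-dichlorophenyl in place of 4-fluorophenyl on an aromatic carbon. Within the data shown here, the one measured step that bears on this change shows no change at the digits printed from compound 1 to compound 2 (within the scatter), and it also alters only the aryl group on that carbon. Among the measured compounds shown here, this is thin evidence, since it rests on a single pair and no measured compound carries a chlorine.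

No step beyond the scatter is therefore expected in this assay, and no direction can be argued from the data. The estimated change is a 1.1-fold lower number from compound 2 to compound 3 (0.04 log units; within the scatter). For compound 3 the expected value is 65000 nM, with an estimated range from 25000 nM to 130000 nM.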

Compound 3, half-maximal inhibitory concentration: 70700 nM
Beside the measured number, compound 3's estimate is 1.1-fold (0.04 log units) below it; measured number inside the range.
By their numbers in this assay, from the lowest: compounds 1, 2 and 3 (each within the scatter of the next).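

Working notes on the aryl position, the aromatic carbon opposite the ring nitrogen. In this assay, 2,3-dichlorophenyl in place of 4-fluorophenyl gives a first step involving chlorine (no change at the digits printed from compound 2 to compound 3 (within the scatter)), and the same group in place of 4-methoxyphenyl reads alike (no change at the digits printed from compound 1 to compound 3 (within the scatter)). This carbon now holds three aryl groups, and compound 3 at 70700 nM shows that an entering group with 8 heavy atoms and two chlorines, replacing one with 7 heavy atoms and one fluorine, does not separate from the other two in this read-out. The level now rests on three compounds rather than a single pair, but no available measurement offers an explanation for it.

All three groups are phenyl rings, so the series leaves open whether a phenyl ring bearing an amine or a carboxylic acid, or a longer alkyl chain in place of the ring, would depart from this level. It also leaves open whether the level is set by the shared core rather than by the aryl group, a question that the three compounds, all changed at this one carbon, cannot settle.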